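The compounds below may be only part of what the source reports. "The series", "measured", "known", "first", "only" and "open" are said of these compounds alone.

Compound 1, `O=c1[nH]nc2n(c1=O)CCN2c1ccccc1`, gives 7% in an ADME assay on Vero cells (Chlorocebus sabaeus) for cytotoxicity, with a stated time of 72 h, tested at 10 ug/mL; on this read-out lower numbers stand for a weaker effect and higher numbers for a stronger effect at the one concentration tested. Compound 2, `N=c1c(=O)[nH]nc2n1CCN2c1ccccc1Cl`, gives 0%. Compound 3, `COc1ccc(N2CCn3c2n[nH]c(=O)c3=O)cc1`, gives 0%.

Compound 3 reads the same as compound 2 at the digits given, and the two share the lowest reading of the three. Within the data shown here, the only measured step between compounds that differ in one place, a number 7 percentage points lower from compound 1 to compound 3 (within the scatter), lies within the scatter, so compound 1 and compound 3 cannot be told apart on this read-out.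

Compound 4, `O=c1[nH]nc2n(c1=O)CCN2c1ccc(Cl)cc1`, has not yet been measured in this assay. It differs from compound 3 as follows: chloro in place of methoxy on an aromatic carbon. Among the measured compounds shown here, the change sits on the same aromatic carbon that was altered in the one measured step, and that step moved the reading by only a number 7 percentage points lower from compound 1 to compound 3 (within the scatter), an amount within the scatter. For the measured compounds named here, no measured step involves a chloro group at this place, and compound 2, which carries a chloro group, differs from compound 3 in more than one place, so it gives no clean step. On this basis no step beyond the scatter is expected for compound 4; the expected step is a number 3 percentage points higher from compound 3 to compound 4 (within the scatter). The estimate for compound 4 is 3%, with a range from 0% to 15%.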

Compound 4, a percentage reported as inhibition, at one concentration (the size of the read-out at that concentration, not a potency): 0%
Estimate against measurement, compound 4: 3 percentage points above; measured number inside the range.
By their numbers in this assay, from the lowest: compounds 2, 3, 4 and 1 (each within the scatter of the next).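

In this assay, the swap of methoxy for chloro on an aromatic carbon para to a large group gives no change at the digits printed from compound 3 to compound 4 (within the scatter), so two quite different groups, one with a carbon and an oxygen and the other a single chlorine atom, cannot be told apart at this place. Measured against the plain hydrogen of the parent compound, chloro gives a number 7 percentage points lower from compound 1 to compound 4 (within the scatter), which means that this place now has two substituents, methoxy and chloro, and neither reads differently from hydrogen on this measure of harm to the cells. Nothing measured here explains this flat picture, and no cause can be offered for it.

On these data alone, whether a group of another kind at this place, such as an amine, a carboxylic acid or a longer chain, would move the reading beyond the usual scatter remains open. The readings also come from one concentration, so they do not show how these compounds would behave at higher doses or give any measure of potency.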